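Swapping Fluoro for Hydrogen on Compound 2

A few compounds are considered here, and "the series" means these few. Any claim that something is new, unique, unknown or untested is made for them only; others in the source may bear on it.

Compound 1 `Cc1c(Cc2ccccc2)c(=O)oc2cc(OCCOc3no[n+]([O-])c3S(=O)(=O)c3ccccc3)ccc12` gives 4540 nM
Compound 2 `COc1cc(OCCOc2no[n+]([O-])c2S(=O)(=O)c2ccccc2)ccc1C(=O)/C=C/c1ccc(F)cc1` gives 1670 nM

In a functional assay on KB cells (Homo sapiens) for antiproliferative activity, read by MTT assay, with a stated time of 48 h (a lower number here means a stronger inhibitor, a higher number a weaker inhibitor), compound 2 gives 1670 nM, the lower of the two numbers and beyond the scatter from compound 1. Compound 3 `COc1cc(OCCOc2no[n+]([O-])c2S(=O)(=O)c2ccccc2)ccc1C(=O)/C=C/c1ccccc1` carries hydrogen in place of fluoro on an aromatic carbon and is otherwise the same as compound 2. For the measured compounds named here, no measured pair shows this change, so the data offer no direction, and no step beyond the scatter is expected in this assay. The estimated step of a 1.1-fold higher number from compound 2 to compound 3 (0.03 log units; within the scatter) is therefore small. Compound 3 is estimated at 1800 nM, with an expected range from 750 nM to 4200 nM.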

Compound 3, half-maximal inhibitory concentration: 2180 nM
The estimate for compound 3 lay 1.2-fold (0.08 log units) below the measured number, within the range that was stated.
By their numbers in this assay, from the lowest: compounds 2 and 3 (each within the scatter of the next); then compound 1.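

Changing 4-fluorophenyl to phenyl gives, in this assay, a 1.3-fold higher number from compound 2 to compound 3 (0.12 log units; within the scatter) and is the only direct comparison at this position among the compounds shown. Fluoro and hydrogen on this aromatic carbon therefore cannot be told apart in this assay, so the fluoro is not required to keep this level of activity. No supporting measurement offers an explanation for this result. Going by these compounds, whether a methoxy group or an amine at this position would shift the number remains open, as does the effect of chloro or a longer chain there.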